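The compounds below may be only part of what the source reports. "The series", "measured", "known", "first", "only" and "open" are said of these compounds alone.

Measured so far:
compound 1, `C=C1CC[C@@H]2[C@](C)(COC(C)=O)[C@H](OC(C)=O)CC[C@@]2(C)[C@@H]1C/C=C1/C(=O)OC[C@H]1OC(C)=O`: 10 uM
compound 2, `C=C1CC[C@@H]2[C@](C)(CO[Si](c3ccccc3)(c3ccccc3)C(C)(C)C)[C@H](OC(C)=O)CC[C@@]2(C)[C@@H]1C/C=C1/C(=O)OC[C@H]1O`: 7.53 uM
compound 3, `C=C1CC[C@@H]2[C@](C)(CO)[C@H](OC(C)=O)CC[C@@]2(C)[C@@H]1C/C=C1/C(=O)OC[C@H]1OC(C)=O`: 11 uM

In a functional assay on MCF7 cells (Homo sapiens) for cytotoxicity, read by sulforhodamine B assay (a higher number here means that more compound is needed for the effect, a lower number that less compound is needed), compound 3 gives 11 uM and compound 1 gives 10 uM, and the two differ by one change, (acetyl in place of hydrogen on an oxygen on a saturated carbon), which made a step of a 1.1-fold lower number from compound 3 to compound 1 (0.04 log units; within the scatter). Compound 2 gives 7.53 uM in this assay; the difference between the core of compound 2 and the core of compound 3 is not broken down here. Compound 4, `C=C1CC[C@@H]2[C@](C)(CO[Si](c3ccccc3)(c3ccccc3)C(C)(C)C)[C@H](OC(C)=O)CC[C@@]2(C)[C@@H]1C/C=C1/C(=O)OC[C@H]1OC(C)=O`, is not yet measured. It differs from compound 2 by acetyl in place of hydrogen on an oxygen on a saturated carbon. This is the same kind of change as that from compound 3 to compound 1, but the place differs: here the oxygen sits on a saturated carbon whose other neighbour is a saturated ring carbon, there a saturated chain carbon. Because the earlier step was a 1.1-fold lower number from compound 3 to compound 1 (0.04 log units; within the scatter), a step of a 1.1-fold lower number from compound 2 to compound 4 (0.03 log units; within the scatter) is expected in this assay. Compound 4 is therefore estimated to give 7 uM, most likely between 3.5 uM and 14 uM.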

Compound 4, concentration for half-maximal effect: 45.7 uM
Compound 4: the middle estimate sits 6.5-fold (0.81 log units) below what was measured; measured number above the stated range.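

In this assay, acetyl in place of hydrogen on an oxygen on a saturated carbon gave a 6.1-fold higher number from compound 2 to compound 4 (0.78 log units; beyond the scatter) on the core of compound 2. The change therefore did not carry over as a fixed step between the two cores: the same change on two cores in this assay, a 1.1-fold lower number (0.04 log units; within the scatter) from compound 3 to compound 1 and a 6.1-fold higher number (0.78 log units; beyond the scatter) from compound 2 to compound 4, 6.7-fold (0.82 log units) apart, beyond the scatter of two such steps. This rests on a single pair for each core, and the oxygen bearing the change sits in a different place in each pair, so it does not show whether the core, the place or both set the steps apart.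

The compounds shown leave open whether a methyl ether or a longer acyl chain such as butanoyl on this oxygen would behave like acetyl on either core.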